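The source may report more compounds than this note shows. Statements on the series, on what has been measured and on what is new or still open speak of the compounds shown alone.

Values in an ADME assay on RD cells (Homo sapiens) for cytotoxicity; on this read-out lower numbers stand for higher toxicity in this test and higher numbers for lower toxicity in this test:

compound 1 `O=C1Nc2ccccc2/C1=N/NC(=S)Nc1ccccc1`: > 25000 nM
compound 2 `Cc1ccccc1NC(=S)N/N=C1\C(=O)Nc2ccccc21`: > 25000 nM
compound 3 `O=C1Nc2ccc(Cl)cc2/C1=N/NC(=S)Nc1ccccc1`: > 25000 nM

Each of these three values is a limit of the assay, not a number. Among the compounds with values here, compound 3 therefore stands at the limit, and its position relative to compound 1 and compound 2 cannot be read; the step that the two limits leave unreadable from compound 1 to compound 3 is unreadable for that reason, as is a step that the two limits leave unreadable from compound 1 to compound 2, which is the only other measured step in this assay. All that is known of the measured compounds is captured by the limit of > 25000 nM in this assay, at which 3 of the 3 values shown sit.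

Compound 4 `Cc1ccc2c(c1)/C(=N/NC(=S)Nc1ccccc1)C(=O)N2` is not yet measured in this assay. It differs from compound 3 by methyl in place of chloro on an aromatic carbon. Within the data shown here, the one measured step that bears on it is a step that the two limits leave unreadable from compound 1 to compound 3, the step that put chloro onto the core, and it gives no readable size in either direction; the methyl step that the two limits leave unreadable from compound 1 to compound 2 is equally silent. No step beyond the scatter is expected, and compound 4 is expected to give 40000 nM in this assay, with a range from 15000 nM to 120000 nM, most likely again as a limit. The expected step is a step that the limit leaves unreadable from compound 3 to compound 4.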

Compound 4, half-maximal cytotoxic concentration: > 25000 nM
Compound 4 ended at the assay's limit; the forecaster's own chance of this, stated with the estimate: 85%; the middle value is on the limit's open side.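

No new step can be read for compound 4 against compound 3 or compound 1 in this assay, with every value a limit of the assay: the limit of > 25000 nM in this assay, at which 4 of the 4 values shown sit.

Left open is how compound 1, compound 2, compound 3 and compound 4 rank against one another in this assay, and at what concentration any of them becomes cytotoxic.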